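Swapping Nitro for Tert-Butyl on a Triazole Ester

The compounds below may be only part of what the source reports. "The series", "measured", "known", "first", "only" and "open" are said of these compounds alone.

These compounds share a large terpenoid core carrying an ester, and they were tested in a functional assay on DU-145 cells (Homo sapiens) for antiproliferative activity, read by MTT assay, with a stated time of 48 h; a higher number here means a weaker inhibitor, a lower number a stronger inhibitor. Compound 1, `C#CCOC(=O)/C(C)=C/CC/C(C)=C/CC/C(C)=C/CC[C@@H]1[C@@]2(C)CCC(=O)C(C)(C)[C@H]2CC[C@@]1(C)O`, keeps the ester as a small propargyl group and gives 46100 nM in this assay. Compound 2, `C/C(=C\CC/C(C)=C/CC[C@@H]1[C@@]2(C)CCC(=O)C(C)(C)[C@H]2CC[C@@]1(C)O)CC/C=C(\C)C(=O)OCc1cn(C[C@@H]2O[C@H](n3ccc(=O)[nH]c3=O)[C@H]3OC(C)(C)O[C@H]32)nn1`, extends the ester through a triazole to a protected nucleoside. For compound 2 this assay reports only a limit of > 150000 nM, not a number. Compound 3, `C/C(=C\CC/C(C)=C/CC[C@@H]1[C@@]2(C)CCC(=O)C(C)(C)[C@H]2CC[C@@]1(C)O)CC/C=C(\C)C(=O)OCc1cn(-c2ccc([N+](=O)[O-])cc2)nn1`, carries a 4-nitrophenyl on the triazole instead. For compound 3 this assay likewise gives only a limit of > 150000 nM, so compound 3 stands among the weakest compounds shown, a point underlined by the limit of > 150000 nM in this assay, at which 2 of the 3 values shown sit. Compound 4, `C/C(=C\CC/C(C)=C/CC[C@@H]1[C@@]2(C)CCC(=O)C(C)(C)[C@H]2CC[C@@]1(C)O)CC/C=C(\C)C(=O)OCc1cn(-c2ccc(C(C)(C)C)cc2)nn1`, differs from compound 3 by tert-butyl in place of nitro on an aromatic carbon. The two limits give no basis for expecting a gain, so compound 4 is expected to stay near the same limit, with an estimated step of a number no higher from compound 3 to compound 4 (the limit leaves the size open) and an estimated value of 150000 nM, within a range from 50000 nM to 500000 nM.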

Compound 4, half-maximal inhibitory concentration: > 150000 nM
Compound 4 ended at the assay's limit; the forecaster's own chance of this, stated with the estimate: 70%; the middle value lies on the limit itself.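

Compound 3 and compound 4 each give only a limit in this assay, not a number, so no step can be read between them: the limit of > 150000 nM in this assay, at which 3 of the 4 values shown sit.

The compounds shown leave open whether tert-butyl and nitro differ at all in this assay, since neither compound has a number.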